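Working notes: the step from compound 3 to compound 4

This account rests on a few compounds, and the source may have more. Where it says the series, first, only, none or still open, it means among the compounds named here.

Compound 1 `COC(=O)CNC(=O)C(CSCc1ccc(Br)cc1)NC(=O)CCC(N)C(=O)O`: in a functional assay on K562 cells (Homo sapiens) for cytotoxicity (on this read-out lower numbers stand for stronger inhibition and higher numbers for weaker inhibition), compound 1 gives > 50 uM, a limit of the assay.
Compound 2 `O=CNC(CCC(=O)NC(CSCc1ccc(Br)cc1)C(=O)NCC(=O)O)C(=O)O`: in this assay compound 2 gives > 50 uM, again a limit.
Compound 3 `CC(=O)NC(CCC(=O)NC(CSCc1ccc(Br)cc1)C(=O)NCC(=O)O)C(=O)O`: in this assay compound 3 gives > 50 uM, also a limit.

Compound 3 thus stands nowhere on a scale; every value in the set is a limit, as summed up by the limit of > 50 uM in this assay, at which 3 of the 3 values shown sit. Within the data shown here, the only single-point step, a step that the two limits leave unreadable from compound 2 to compound 3, is unreadable for the same reason. Compound 4 `O=C(O)CNC(=O)C(CSCc1ccc(Br)cc1)NC(=O)CCC(NC(=O)OCc1ccccc1)C(=O)O` differs from compound 3 by benzyloxy in place of methyl on a carbonyl carbon. Among the measured compounds shown here, no measured step bears on this change, and nothing in the set has moved off the limit. Compound 4 is therefore expected to stay at the limit as well, the step from compound 3 to compound 4 being estimated as a number no higher from compound 3 to compound 4 (the limit leaves the size open). The estimate for compound 4 in this assay is 50 uM, within a range from 20 uM to 100 uM.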

Compound 4, concentration for 50% inhibition: > 50 uM
Compound 4 gave a limit, no number; the forecaster's own chance of this, stated with the estimate: 80%; the middle value sits exactly at the limit.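

No step can be read from compound 2 or compound 3 to compound 4, because all values remain limits, not numbers: the limit of > 50 uM in this assay, at which 4 of the 4 values shown sit. The compounds shown leave open the size and direction of every change in this series.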